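From Phenyl to Butyl on an Amide-Type Nitrogen

The source may hold more compounds than are shown below. What is called first, only, known or untested is meant among the compounds shown, and "the series" means these compounds.

Of the compounds shown here, three sharing one core have been measured in a functional assay on the whole organism (blood, strain albino) with Mus musculus as the target, with stated times of 6 days and 4 h, at a dose of 0.4 mmol/kg by the oral route; a lower number here means less inhibition, a higher number more inhibition at the dose given (going by the name of the read-out). Compound 1 `Cc1cc(C(=O)O)nn1-c1ccc(S(=O)(=O)NC(=S)NCc2ccccc2)cc1` gives only a limit of the assay, < 2%. Compound 2 `Cc1cc(C(=O)O)nn1-c1ccc(S(=O)(=O)NC(=S)Nc2ccccc2)cc1` gives 0%, and compound 3 `Cc1cc(C)n(-c2ccc(S(=O)(=O)NC(=S)Nc3ccccc3)cc2)n1` gives -3%. Among the two numbers shown, compound 3 stands lowest, with compound 2 nearest, the step of a number 3 percentage points lower from compound 2 to compound 3 (within the scatter). The step that the limit leaves unreadable from compound 1 to compound 2 concerns the same amide-type nitrogen that is changed here, but the limit of compound 1 leaves its size unknown (the limit of < 2% in this assay, at which 1 of the 3 values shown sits).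

Compound 4 `CCCCNC(=S)NS(=O)(=O)c1ccc(-n2nc(C)cc2C)cc1` differs from compound 3 by butyl in place of phenyl on an amide-type nitrogen. Going by the values given here, no measured step shows in readable form what a change on that nitrogen does, and the one step that touches it is unreadable. All numbers shown in this assay sit near zero, so compound 4 is expected to stay there as well, the expected step being a number 3 percentage points higher from compound 3 to compound 4 (within the scatter). Compound 4 is therefore estimated at 0%, with a range from -10% to 10%.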

Compound 4, a percentage reported as inhibition, in the whole organism at one dose (the size of the read-out at that dose, not a potency): 1%
The estimate for compound 4 lay 1 percentage points below the measured number; measured number inside the range.
By their numbers in this assay, from the lowest: compounds 3, 2 and 4 (each within the scatter of the next).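

Going by these compounds alone, the change from phenyl to butyl gives the first readable step on the amide-type nitrogen in this assay, a number 4 percentage points higher from compound 3 to compound 4 (within the scatter). Replacing the aromatic ring with an open chain on this nitrogen therefore leaves the read-out within the scatter at this dose, so the position has not yet shown any sensitivity to the group it carries. Compound 1 gives only a limit, so the earlier step on this nitrogen cannot be read: the limit of < 2% in this assay, at which 1 of the 4 values shown sits.

Going by these compounds, it remains open whether a longer chain such as octyl, or a butyl chain ending in an amine or a carboxylic acid, would move the read-out away from zero. On these data alone, it is also open whether butyl on this nitrogen would behave the same way with carboxy on the aromatic carbon, as in compound 2.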